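The compounds below may be only part of what the source reports. "The series", "measured", "known", "first", "only" and "open" are said of these compounds alone.

Measured so far:
compound 1 `COc1ccc(N(C(=O)CN2C=CN(c3ccccc3)C(=O)[C@@H](Cc3n[nH]c4ccccc34)C2=O)C(C)C)cc1` gives 1550 nM in a functional assay on CHO cells for agonist activity at Melanocyte-stimulating hormone receptor (Homo sapiens), read by a luciferase reporter, with a stated time of 4 h; a higher number here means that more compound is needed for the effect, a lower number that less compound is needed;
compound 2 `COc1ccc(N(C(=O)CN2C=CN(c3ccccc3)C(=O)C(Cc3n[nH]c4ccccc34)C2=O)C(C)C)cc1` gives 29.5 nM in this assay.

Compound 2 therefore stands lowest of the two numbers. Among the measured compounds shown here, the single measured step, a 53-fold lower number from compound 1 to compound 2 (1.72 log units; beyond the scatter), is tied to the fact that one of compounds 1 and 2 is drawn with a defined configuration and the other without, at the place where they differ, a difference in drawn configuration rather than in atoms. Compound 3 `COc1ccc(N(C(=O)CN2C=CN(c3ccccc3)C(=O)C(Cc3cc[nH]n3)(Cc3n[nH]c4ccccc34)C2=O)C(C)C)cc1` differs from compound 2 by (1H-pyrazol-3-yl)methyl in place of hydrogen on a saturated ring carbon. For the measured compounds named here, no measured step tests a group added at that carbon, so the size and direction of the change are open. For compound 3 the estimated value is 150 nM, with a range from 20 nM to 1500 nM, which would be an expected 5.1-fold higher number from compound 2 to compound 3 (0.71 log units; beyond the scatter).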

Compound 3, half-maximal effective concentration: 398 nM
Estimate against measurement, compound 3: 2.7-fold (0.42 log units) below; low and high end bracket the measured number.
By their numbers in this assay, from the lowest: compound 2; then compound 3; then compound 1.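

In this assay, (1H-pyrazol-3-yl)methyl in place of hydrogen on this saturated ring carbon gives a 13-fold higher number from compound 2 to compound 3 (1.13 log units; beyond the scatter). Among the compounds shown here, this is the first measured change that adds a group at this carbon: compound 3 still gives a measurable response, but more compound is needed for the effect. Nothing given accounts for the size of this step.

Still open, as far as these compounds go, is whether a plain methyl, an aminomethyl or a carboxylic acid on the same carbon would give a number closer to that of compound 2. Also open, from the compounds shown here alone, is whether a drawn configuration at this carbon would change the number of compound 3.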